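The source may hold more compounds than are shown below. What is called first, only, known or untested is meant among the compounds shown, and "the series" means these compounds.

In an assay on isolated protein for displacement of a labelled ligand from acyl-CoA:cholesterol acyltransferase (Oryctolagus cuniculus) (a lower number here means a stronger inhibitor, a higher number a weaker inhibitor), three compounds have been measured:

compound 1, `CC(C)c1cccc(C(C)C)c1NC(=O)Nc1nc2ccccc2n1-c1ccccc1Cl`, 18 nM
compound 2, `CC(C)c1cccc(C(C)C)c1NC(=O)Nc1nc2ccccc2n1-c1ccccc1Br`, 22 nM
compound 3, `CC(C)c1cccc(C(C)C)c1NC(=O)Nc1nc2ccccc2n1-c1ccccc1O`, 200 nM

Compound 1 gives the lowest number of the three. Its nearest neighbour is compound 2, with a 1.2-fold higher number from compound 1 to compound 2 (0.09 log units; within the scatter), a difference within the scatter; its furthest is compound 3, with an 11-fold higher number from compound 1 to compound 3 (1.05 log units; beyond the scatter). Compound 4, `CC(C)c1cccc(C(C)C)c1NC(=O)Nc1nc2ccccc2n1-c1ncccc1Cl`, has not yet been measured. It differs from compound 1 in one place: 3-chloropyridin-2-yl in place of 2-chlorophenyl on an aromatic nitrogen. The chloro group is kept, so the measured steps bear on it only indirectly. The step of a 1.2-fold higher number from compound 1 to compound 2 (0.09 log units; within the scatter) shows that exchanging one halogen for another leaves the number essentially where it was, while an 11-fold higher number from compound 1 to compound 3 (1.05 log units; beyond the scatter) shows that putting a hydroxy group in place of the chloro costs a great deal. For the measured compounds named here, no measured step exchanges a ring carbon for a ring nitrogen in this group. The account therefore expects for compound 4 a small step or none beyond the scatter, estimated as a 1.7-fold higher number from compound 1 to compound 4 (0.22 log units; within the scatter). Compound 4 is estimated at 30 nM, with a range from 10 nM to 100 nM.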

Compound 4, half-maximal inhibitory concentration: 100 nM
For compound 4 the middle estimate is 3.3-fold (0.52 log units) below the measured one, and the stated range covers the measured number.
By their numbers in this assay, from the lowest: compounds 1 and 2 (each within the scatter of the next); then compounds 4 and 3 (each within the scatter of the next).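

In this assay, the group on the aromatic nitrogen proves sensitive to more than the substituent it carries: with the chloro kept, 3-chloropyridin-2-yl in place of 2-chlorophenyl gives a 5.6-fold higher number from compound 1 to compound 4 (0.74 log units; beyond the scatter), and the comparison with the bromo compound reads much the same, a 4.5-fold higher number from compound 2 to compound 4 (0.66 log units; beyond the scatter). A change in the ring itself can therefore cost about as much as losing the halogen to a hydroxy group, as a 2.0-fold lower number from compound 3 to compound 4 (0.30 log units; within the scatter) puts these two replacements within the scatter of each other. Nothing measured here tells why the ring nitrogen carries this cost.

The compounds shown leave open whether a methyl or methoxy group in place of the chloro would keep the number near that of compound 1. They also leave open whether the ring nitrogen would cost as much in a ring carrying bromo.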